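The source may hold more compounds than are shown below. What is called first, only, known or untested is meant among the compounds shown, and "the series" means these compounds.

Of the compounds shown here, three that share one core have been measured in a functional assay on MDA-MB-231 cells (Homo sapiens) for cytotoxicity, read by MTT assay, with a stated time of 24 h; a lower number here means a stronger inhibitor, a higher number a weaker inhibitor. Compound 1 `CCCCCCCCCCCC(=O)Nc1nnc(S[C@@H]2O[C@H](CO)[C@H](O)[C@H](O)[C@H]2O)s1` gives 32000 nM. Compound 2 `CCCCCCCCCC(=O)Nc1nnc(S[C@@H]2O[C@H](COC(C)=O)[C@H](OC(C)=O)[C@H](OC(C)=O)[C@H]2OC(C)=O)s1` gives 19200 nM, and compound 3 `CCCCCCCCCCCC(=O)Nc1nnc(S[C@@H]2O[C@H](COC(C)=O)[C@H](OC(C)=O)[C@H](OC(C)=O)[C@H]2OC(C)=O)s1` gives 26700 nM. Compound 1 thus shows the highest of the three numbers, but its gap to compound 3 and its gap to compound 2 both lie within the scatter, so no ordering among the three can be read from these values. Among the measured compounds shown here, the only step between two compounds that differ in a single place, a 1.4-fold higher number from compound 2 to compound 3 (0.14 log units; within the scatter), is likewise within the scatter.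

Compound 4 `CCCCCCCCCCCCCCCC(=O)Nc1nnc(S[C@@H]2O[C@H](CO)[C@H](O)[C@H](O)[C@H]2O)s1` is compound 1 with butyl in place of hydrogen on a saturated chain carbon, ten or more bonds along the chain from a carbonyl carbon. For the measured compounds named here, the step from compound 2 to compound 3, which set ethyl in place of hydrogen on a saturated chain carbon, is the one measured change of the same kind, and it produced no movement beyond the scatter. Compound 4 is therefore expected to show a step of a 1.3-fold higher number from compound 1 to compound 4 (0.10 log units; within the scatter) in this assay, within the scatter and, if anything, toward a higher number. Compound 4 is estimated at 40000 nM, with a range from 20000 nM to 80000 nM.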

Compound 4, half-maximal inhibitory concentration: 62300 nM
Compound 4: middle estimate off by 1.6-fold (0.19 log units), on the low side; measured number inside the range.
By their numbers in this assay, from the lowest: compounds 2, 3, 1 and 4 (each within the scatter of the next, the first and the last beyond it).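

In this assay, butyl in place of hydrogen on a saturated chain carbon, ten or more bonds along the chain from a carbonyl carbon, gives a 1.9-fold higher number from compound 1 to compound 4 (0.29 log units; within the scatter) and so extends the chain comparison to the compounds with free hydroxyl groups on the shared core. Set beside a 1.4-fold higher number from compound 2 to compound 3 (0.14 log units; within the scatter), measured on the compounds with acetyl esters, it shows the chain change in both forms, with neither step leaving the scatter, although the new step lies close to its edge and both point toward a higher number. No measurement on these compounds accounts for these numbers.

The compounds shown leave open whether a longer chain than that of compound 4 would carry the number clearly beyond the scatter of compound 1, or whether the trend would hold with a chain shorter than that of compound 1. They also leave open what an amine or a carboxylic acid at the far end of the chain would do in this assay in place of the plain saturated end.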